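From tert-butyl to benzyl ester at the assay limit

This account rests on a few compounds, and the source may have more. Where it says the series, first, only, none or still open, it means among the compounds named here.

Values measured in a functional assay on Raji cells (Homo sapiens) for cytotoxicity, with a stated time of 72 h (on this read-out higher numbers stand for an effect only at larger amounts of compound and lower numbers for an effect already at smaller amounts), are these:
- Compound 1 `C=C[C@@](C)(/C=C/c1ccc(O)c(/C=C/C(=O)OCc2ccccc2)c1)CCC=C(C)C` gives > 26000 nM as a limit
- Compound 2 `COc1ccc(/C=C/[C@@](C)(/C=C/c2ccc(O)c(C=O)c2)CCC=C(C)C)cc1` gives 13000 nM
- Compound 3 `COc1ccc(/C=C/[C@@](C)(/C=C/c2ccc(O)c(/C=C/C(=O)OC(C)(C)C)c2)CCC=C(C)C)cc1` gives > 26000 nM as a limit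

Compound 3 stands at the limit of > 26000 nM in this assay, at which 2 of the 3 values shown sit, and so has only a limit, not a number. Compound 4 `COc1ccc(/C=C/[C@@](C)(/C=C/c2ccc(O)c(/C=C/C(=O)OCc3ccccc3)c2)CCC=C(C)C)cc1` differs from it by benzyl in place of tert-butyl on an oxygen next to a carbonyl group with benzyl in place of tert-butyl on an oxygen next to a carbonyl group. Among the measured compounds shown here, the one measured step of an at least 2.0-fold higher number from compound 2 to compound 3 (0.30 log units; that floor lies within the scatter) concerns a different change and does not test this one. Compound 1 also carries 2-(benzyloxycarbonyl)ethenyl and its > 26000 nM is likewise a limit. No step beyond the scatter is therefore expected in this assay and another limit is likely. The expected step is a number no higher from compound 3 to compound 4 (the limit leaves the size open) in this estimate. Compound 4 is estimated at 26000 nM with an expected range from 13000 nM to 52000 nM if a number is obtained.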

Compound 4, half-maximal effective concentration: > 26000 nM
Compound 4: a limit, no number (the forecaster's own chance of this, stated with the estimate: 75%); the middle value lies on the limit itself.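

In this assay the exchange of tert-butyl for benzyl on an oxygen next to a carbonyl group yields no number, and the steps to compound 4 from compound 3 and from compound 1 cannot be read. Among the compounds shown here, the only step that can be read is an at least 2.0-fold higher number from compound 2 to compound 4 (0.30 log units; that floor lies within the scatter). Tert-butyl and benzyl esters thus end at the same limit: the limit of > 26000 nM in this assay, at which 3 of the 4 values shown sit.

The compounds shown leave open whether any ester here would give a number. They also leave open whether a carboxylic acid or an amide in its place would give one.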